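Halogen exchange on the pendant aryl: cytotoxicity notes

This account rests on a few compounds, and the source may have more. Where it says the series, first, only, none or still open, it means among the compounds named here.

Compound 2 `Cc1cc(-c2cc(F)cc(F)c2)cc(C)c1Nc1ccnc(Nc2ccc(C#N)cc2)n1` gives 3910 nM in an ADME assay on MT4 cells (Homo sapiens) for cytotoxicity, read by MTT assay, with a stated time of 4 days (on this read-out higher numbers stand for lower toxicity in this test and lower numbers for higher toxicity in this test), the highest of the two numbers recorded; its nearest neighbour, compound 1 `Cc1cc(-c2cccc(C#N)c2)cc(C)c1Nc1ccnc(Nc2ccc(C#N)cc2)n1`, gives 920 nM in this assay. For the measured compounds named here, the only step measured so far, a 4.3-fold higher number from compound 1 to compound 2 (0.63 log units; beyond the scatter), concerns a different change of the pendant aryl group and is a modest one. Compound 3 `Cc1cc(-c2cc(Cl)cc(Cl)c2)cc(C)c1Nc1ccnc(Nc2ccc(C#N)cc2)n1` carries the change (3,5-dichlorophenyl in place of 3,5-difluorophenyl on an aromatic carbon), sitting on an aromatic carbon of the shared core that is meta to two methyl groups and para to a large group. Going by the values given here, no measured step covers an exchange of one halogen pair for another on this ring, so the step from compound 1 to compound 2 offers only a loose sense of scale. The expected step, a 1.3-fold lower number from compound 2 to compound 3 (0.12 log units; within the scatter), stays within the scatter, with a slight lean toward a lower number. Compound 3 is estimated at 3000 nM in this assay, with a range of 1000 nM to 9000 nM.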

Compound 3, half-maximal cytotoxic concentration: 4290 nM
The estimate for compound 3 lay 1.4-fold (0.16 log units) below the measured number; the range from low to high includes it.
By their numbers in this assay, from the lowest: compound 1; then compounds 2 and 3 (each within the scatter of the next).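

In this assay the exchange of 3,5-difluorophenyl for 3,5-dichlorophenyl on this aromatic carbon gives a 1.1-fold higher number from compound 2 to compound 3 (0.04 log units; within the scatter) and so leaves compound 2 and compound 3 indistinguishable on this read-out. The second halogen pair also stands apart from the 3-cyanophenyl group, with a 4.7-fold higher number from compound 1 to compound 3 (0.67 log units; beyond the scatter) as a second case beside a 4.3-fold higher number from compound 1 to compound 2 (0.63 log units; beyond the scatter) and with both steps beyond the scatter. Nothing available here accounts for either the flat halogen exchange or the gap to compound 1.

Open is whether that gap follows the nitrile itself or the change from one substituent to two on the pendant ring, as the compounds shown change both together. Also open, as far as these compounds go, is how a pendant ring bearing an amine or a carboxylic acid would read in this assay, since only nitrile and halogen substituents appear here.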